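The source may hold more compounds than are shown below. What is called first, only, known or untested is meant among the compounds shown, and "the series" means these compounds.

Measured so far:
compound 1, `COC(=O)c1cccc(C(=O)N2CCC(N(C3CC3)S(=O)(=O)c3cccc(C(F)(F)F)c3)CC2)c1`: "not determined" (no result reported)
compound 2, `CS(=O)(=O)c1ccc(C(=O)N2CCC(N(C3CC3)S(=O)(=O)c3cccc(C(F)(F)F)c3)CC2)cc1`: "not determined" (no result reported)
compound 3, `CS(=O)(=O)c1ccc(F)cc1C(=O)N1CCC(N(C2CC2)S(=O)(=O)c2cccc(C(F)(F)F)c2)CC1`: 18%

In an assay on cells for inhibition of Voltage-dependent L-type calcium channel subunit alpha-1C (Homo sapiens), read by FLIPR and calcium flux, tested at 1 uM (on this read-out lower numbers stand for a weaker effect and higher numbers for a stronger effect at the one concentration tested), compound 3 gives 18%. For the measured compounds named here, this is the only number in the set; compound 1 and compound 2 carry no result in this assay, so compound 3 stands alone and no ordering can be drawn from it. Going by the values given here, with no step between measured compounds available, the size of any step remains untested, and the single reading of compound 3 at 18% is the sole anchor.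

Compound 4, `NC(=O)c1ccc(C(=O)N2CCC(N(C3CC3)S(=O)(=O)c3cccc(C(F)(F)F)c3)CC2)cc1`, is not yet measured. It differs from compound 3 in one place: 4-carbamoylphenyl in place of 5-fluoro-2-(methylsulfonyl)phenyl on a carbonyl carbon. The change is confined to the aryl group on the carbonyl carbon whose other neighbour is the amide-type nitrogen in the ring, and the rest of the shared core is kept.

The step of a number 3 percentage points lower from compound 3 to compound 4 (within the scatter) is expected to be small, within the usual scatter, with no clear direction. Compound 4 is therefore estimated at 15% in this assay, with a range from 0% to 40%.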

Compound 4, a percentage reported as inhibition, at one concentration (the size of the read-out at that concentration, not a potency): 0%
Compound 4: the middle estimate sits 15 percentage points above what was measured, and the stated range covers the measured number.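

In this assay, 4-carbamoylphenyl in place of 5-fluoro-2-(methylsulfonyl)phenyl on a carbonyl carbon gives a number 18 percentage points lower from compound 3 to compound 4 (beyond the scatter), the first sign in the series that the read-out responds to the aryl group at this position. The fluorine, the methylsulfonyl group and the carbamoyl group all change in this one swap, so the step cannot be assigned to any one of them. No measured data on hand bear on why the read-out falls.

On these data alone, what a carboxylic acid or a primary amine on the same phenyl ring would give in this assay remains open. Also open, as far as these compounds go, is whether any aryl group at this position can lift the read-out above that of compound 3 at 18%.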